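The compounds below may be only part of what the source reports. "The series", "measured", "known", "first", "only" and "open" are said of these compounds alone.

Measured so far in a functional assay on CHO cells for antagonist activity at prostaglandin E2 receptor EP3 subtype (Homo sapiens), read by cAMP accumulation; a lower number here means a stronger inhibitor, a higher number a weaker inhibitor:
- compound 1 `CC(C)C(c1ccc(-c2ccc3cccc(F)c3c2)[nH]c1=O)N1CCCCS1(=O)=O` — 122 nM
- compound 2 `CC(C)C(c1ccc(-c2ccc3cccc(F)c3c2)[nH]c1=O)N1CCCCC1=O` — 40 nM
- compound 3 `CC(C)C(c1noc(=O)[nH]1)c1ccc(-c2ccc3cccc(F)c3c2)[nH]c1=O` — 41 nM

Compound 3 stands second highest of the three numbers in this assay. Its nearest neighbour is compound 2, with a 1.0-fold higher number from compound 2 to compound 3 (0.01 log units; within the scatter), so the two show the same potency within the scatter; the furthest is compound 1, and the change from compound 1 to compound 3 was a 3.0-fold lower number from compound 1 to compound 3 (0.47 log units; beyond the scatter).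

Compound 4 `CC(C)NC(=O)CC(c1ccc(-c2ccc3cccc(F)c3c2)[nH]c1=O)C(C)C` differs from compound 3 by a group of 7 heavy atoms (5 carbon, 1 nitrogen, 1 oxygen; no ring) in place of a group of 6 heavy atoms (2 carbon, 2 nitrogen, 2 oxygen; one five-membered aromatic ring with 3 hetero atoms), on a saturated chain carbon bound to an aromatic carbon and a saturated chain carbon. Among the compounds with values here, no measured step makes this same exchange. What bears on it is that all three prior compounds vary only at this position: a 3.1-fold lower number from compound 1 to compound 2 (0.48 log units; beyond the scatter) and a 3.0-fold lower number from compound 1 to compound 3 (0.47 log units; beyond the scatter) were modest, and a 1.0-fold higher number from compound 2 to compound 3 (0.01 log units; within the scatter) was nil. Swapping the group on this carbon has therefore moved this assay by at most a modest amount. For compound 4 a step of similar or smaller size is expected, a 1.5-fold higher number from compound 3 to compound 4 (0.17 log units; within the scatter), with no clear direction. Compound 4 is estimated at 60 nM, with a range from 20 nM to 180 nM.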

Compound 4, half-maximal inhibitory concentration: 15 nM
Beside the measured number, compound 4's estimate is 4.0-fold (0.60 log units) above it, outside the stated range (below it).
By their numbers in this assay, from the lowest: compound 4; then compounds 2 and 3 (each within the scatter of the next); then compound 1.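

In this assay the open-chain (isopropylcarbamoyl)methyl group gives the lowest number seen on this saturated chain carbon, with a 2.7-fold lower number from compound 3 to compound 4 (0.44 log units; beyond the scatter) and a 2.7-fold lower number from compound 2 to compound 4 (0.43 log units; beyond the scatter) and, over the widest span, an 8.1-fold lower number from compound 1 to compound 4 (0.91 log units; beyond the scatter). This shows that a ring in this group is not needed for inhibition here, and that the level shared by compound 2 and compound 3 was not the floor for this position, as the ring-bearing groups alone had suggested. No measurement shown explains why this group lowers the number.

The compounds shown leave open which part of the (isopropylcarbamoyl)methyl group carries the change, since the isopropyl and the amide are present only together in compound 4. A carboxylic acid, a primary amide or a longer chain on this carbon would help separate these parts.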